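From compound 3 to compound 4 in cell toxicity

This account rests on a few compounds, and the source may have more. Where it says the series, first, only, none or still open, it means among the compounds named here.

- Compound 1 `CCC(=O)Oc1[nH]c2ccccc2c1Cc1c(OC(C)=O)ccc2ccc(=O)oc12` gives (67000 nM)
- Compound 2 `Cc1cc(=O)oc2c(CN3CCN(C/C=C/c4ccccc4)CC3)c(OC(=O)c3ccccc3)ccc12` gives (45000 nM)
- Compound 3 `Cc1[nH]c2ccccc2c1Cc1c(OC(=O)CCCC(=O)O)ccc2c(C)cc(=O)oc12` gives (29000 nM)

All three compounds were tested in an ADME assay on MT4 cells (Homo sapiens) for cytotoxicity, read by MTT assay, with a stated time of 96 h; on this read-out higher numbers stand for lower toxicity in this test and lower numbers for higher toxicity in this test. Compound 1 (67000 nM) and compound 3 (29000 nM) differ, with compound 3 on the lower side. That gap lies beyond the usual scatter. Compound 3 lies within the scatter of compound 2 (45000 nM).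

Compound 4 `CCC(=O)Oc1ccc2c(C)cc(=O)oc2c1Cc1c(C)[nH]c2ccccc12` has not yet been measured. Its structure differs from that of compound 3 in one place (hydrogen in place of carboxymethyl on a saturated chain carbon, two bonds along the chain from a carbonyl carbon): hydrogen takes the place of carboxymethyl on a saturated chain carbon, two bonds along the chain from a carbonyl carbon. Cut one bond further out, the same difference reads (3-carboxypropyl)carbonyl to propanoyl.

Among the measured compounds shown here, no two measured compounds differ in only one place, so the data do not show what this change does on its own. A modest step toward higher numbers in this assay is expected, perhaps no larger than the scatter. The basis is thin: the measured compounds differ widely in structure, yet they reach only from compound 3 (29000 nM) to compound 1 (67000 nM). The estimated step reads (a 1.4-fold higher number from compound 3 to compound 4 (0.14 log units; within the scatter)). The estimate for compound 4 is (40000 nM), with an expected range (15000 nM to 100000 nM).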

Compound 4, half-maximal cytotoxic concentration: 31000 nM
Compound 4: middle estimate off by 1.3-fold (0.11 log units), on the high side; measured number inside the range.
By their numbers in this assay, from the lowest: compounds 3, 4, 2 and 1 (each within the scatter of the next, the first and the last beyond it).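

Among the compounds shown here, the pair gives the first direct reading of a single change: in this assay, putting hydrogen in place of carboxymethyl on a saturated chain carbon, two bonds along the chain from a carbonyl carbon, gives a 1.1-fold higher number from compound 3 to compound 4 (0.03 log units; within the scatter). The carboxymethyl group leaves with its hydrogen-bond donor and acceptor and its double bond, turning the (3-carboxypropyl)carbonyl group into propanoyl, yet this test does not separate the two compounds, so in this one pair the end of the chain makes no visible difference. No other measurement accompanies this pair, so the data offer no explanation for why the two compounds read alike.

From the compounds shown here alone, compound 1 and compound 2 differ from this pair in more than one place, so it remains open whether the same change would read alike on their structures. For the compounds shown here, also open is what an amine at the end of the chain, or a chain longer than the one in compound 3, would do at this position, since a single pair cannot show how far this tolerance extends.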